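Swapping isopropyl for cyclobutyl: an expected binding value

The source may report more compounds than this note shows. Statements on the series, on what has been measured and on what is new or still open speak of the compounds shown alone.

Measured so far:
- compound 1 `CCNC(=O)OC[C@H]1OC(n2cnc3c(NC4CCOC4)ncnc32)[C@H](O)[C@@H]1O`: 167 nM
- compound 2 `CC(C)/N=C(\S)OC[C@H]1OC(n2cnc3c(NC4CCOC4)ncnc32)[C@H](O)[C@@H]1O`: 36 nM

For the measured compounds named here, in an assay on DDT1 cells (Cricetulus griseus) for binding affinity to adenosine receptor A1 (Homo sapiens), read by radioligand binding (on this read-out lower numbers stand for stronger inhibition and higher numbers for weaker inhibition), compound 2 gives the lower of the two numbers; its only neighbour is compound 1, and the single measured step, a 4.6-fold lower number from compound 1 to compound 2 (0.67 log units; beyond the scatter), lies beyond the scatter. Compound 3 `O[C@@H]1[C@@H](CO/C(S)=N/C2CCC2)OC(n2cnc3c(NC4CCOC4)ncnc32)[C@@H]1O` differs from compound 2 by cyclobutyl in place of isopropyl on a double-bonded nitrogen. Going by the values given here, none of the measured steps touches this part of the molecule: the step from compound 1 to compound 2 concerns the group attached to the oxygen on the saturated carbon, not the group on the double-bonded nitrogen. So there is no measured basis for a direction, and in this assay no change beyond the scatter is expected. Compound 3 is therefore estimated at 30 nM, within a range from 12 nM to 90 nM. That estimate means a step of a 1.2-fold lower number from compound 2 to compound 3 (0.08 log units; within the scatter), which is expected to stay within the usual scatter.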

Compound 3, inhibition constant: 148 nM
Beside the measured number, compound 3's estimate is 4.9-fold (0.69 log units) below it, outside the stated range (above it).
By their numbers in this assay, from the lowest: compound 2; then compounds 3 and 1 (each within the scatter of the next).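

In this assay, the group on the double-bonded nitrogen clearly matters: cyclobutyl in place of isopropyl gives a 4.1-fold higher number from compound 2 to compound 3 (0.61 log units; beyond the scatter), so this position responds to a change between two plain carbon groups, neither of which has hydrogen-bond donors or acceptors or a net charge. With cyclobutyl, the edge that isopropyl gave is gone, leaving a 1.1-fold lower number from compound 1 to compound 3 (0.05 log units; within the scatter), so the sulfur-bearing group does not bring a lower number with every substituent on its nitrogen. Nothing measured here gives a reason for this shift.

On these data alone, it remains open how methyl, cyclopropyl or a longer chain such as n-butyl would behave on the same nitrogen. With only isopropyl and cyclobutyl to compare at this position, the compounds shown cannot separate the effect of the ring from that of the extra carbon.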